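Inverting one stereocentre in a small spiro series

The source may hold more compounds than are shown below. What is called first, only, known or untested is meant among the compounds shown, and "the series" means these compounds.

Measured in a functional assay on MDA-MB-231 cells (Homo sapiens) for inhibition, read by MTT assay, with a stated time of 72 h; a higher number here means a weaker inhibitor, a lower number a stronger inhibitor:
compound 1 `CC1=NN(c2ccccc2)C(=O)[C@@]12C(=O)C=CC[C@H]2c1ccc(C)cc1`: 8300 nM
compound 2 `CC1=NN(c2ccccc2)C(=O)[C@@]12C(=O)C=CC[C@H]2c1cccc(C)c1`: 6610 nM
compound 3 `CC1=NN(c2ccccc2)C(=O)[C@]12C(=O)C=CC[C@H]2c1ccccc1`: 5800 nM

In this assay compound 3 gives 5800 nM, a value within the scatter of those of compound 1 and compound 2, so the three cannot be ranked. The next compound, compound 4 `CC1=NN(c2ccccc2)C(=O)[C@@]12C(=O)C=CC[C@H]2c1ccccc1`, has the same atoms and bonds as compound 3: the two compounds have the same atoms and bonds and differ only in configuration as drawn: 1 of 2 stereo elements differ; a stereocentre at a saturated ring carbon is drawn S in compound 3 and R in compound 4. A stereocentre at a saturated ring carbon is drawn S in compound 3 and R in compound 4. For the measured compounds named here, only one measured step exists, a 1.3-fold lower number from compound 1 to compound 2 (0.10 log units; within the scatter), and it exchanges 4-methylphenyl for 3-methylphenyl without testing configuration. Going by the values given here, the data therefore contain no measured step of configuration alone, and a change of that kind could still prove larger. Among the compounds with values here, with only that small step as a guide, the expectation is a 1.0-fold higher number from compound 3 to compound 4 (0.01 log units; within the scatter), with no shift beyond the scatter in either direction. For compound 4 the estimated value in this assay is 6000 nM, with an expected range of 2500 nM to 14000 nM.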

Compound 4, half-maximal inhibitory concentration: 5500 nM
Beside the measured number, compound 4's estimate is 1.1-fold (0.04 log units) above it, within the range that was stated.
By their numbers in this assay, from the lowest: compounds 4, 3, 2 and 1 (each within the scatter of the next).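

In this assay, for the compounds shown here, the step of a 1.1-fold lower number from compound 3 to compound 4 (0.02 log units; within the scatter) gives the first measured reading of configuration alone, and it shows that drawing this saturated ring carbon as S or R leaves the number within the scatter. This reading rests on a clean comparison: the fact that compounds 3 and 4 differ only in the configuration as drawn. The steps with hydrogen in place of methyl on an aromatic carbon, a 1.2-fold lower number from compound 2 to compound 4 (0.08 log units; within the scatter) and a 1.5-fold lower number from compound 1 to compound 4 (0.18 log units; within the scatter), also stay within the scatter, so neither 3-methylphenyl nor 4-methylphenyl separates from compound 4 in this assay.

The compounds shown leave open whether the second stereo element has any bearing on the number, since only one of the two is changed here. They also leave open whether a group other than methyl on that aromatic ring, such as an amine or a carboxylic acid, would move the number beyond the scatter.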